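Methylating a ring nitrogen in an antiproliferative amide series

The source may hold more compounds than are shown below. What is called first, only, known or untested is meant among the compounds shown, and "the series" means these compounds.

Two close relatives open this set. Compound 1 `O=C(Nc1ccc(Oc2ccnc3[nH]ccc23)cc1)c1cc2cccnc2n(-c2ccc(Br)cc2)c1=O` stands as "not determined" (no result reported) in a functional assay on NCI-H460 cells (Homo sapiens) for antiproliferative activity, read by MTT assay, with a stated time of 72 h (a higher number here means a weaker inhibitor, a lower number a stronger inhibitor), with no result reported. Within the data shown here, compound 2 `COc1ccc(-n2c(=O)c(C(=O)Nc3ccc(Oc4ccnc5[nH]ccc45)cc3)cc3cccnc32)cc1` gives 960 nM in this assay, and that is the only number available, so compound 2 is the sole point of reference. Compound 3 `COc1ccc(-n2c(=O)c(C(=O)Nc3ccc(Oc4ccnc5c4ccn5C)cc3)cc3cccnc32)cc1` differs from compound 2 in a single spot: methyl in place of hydrogen on an aromatic nitrogen, which leaves the remainder of the shared core untouched. Among the measured compounds shown here, no measured pair in this set shows what such a change does, so the expectation for compound 3 rests on compound 2 alone. The step from compound 2 to compound 3 is expected to weaken inhibition beyond the usual scatter, as a 3.1-fold higher number from compound 2 to compound 3 (0.49 log units; beyond the scatter). Compound 3 is accordingly estimated at 3000 nM, with a plausible span from 1000 nM to 12000 nM.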

Compound 3, half-maximal inhibitory concentration: 1920 nM
The estimate for compound 3 lay 1.6-fold (0.19 log units) above the measured number, and the stated range covers the measured number.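

In this assay, the swap of hydrogen for methyl on an aromatic nitrogen of the five-membered ring gives a 2.0-fold higher number from compound 2 to compound 3 (0.30 log units; within the scatter) and so the two compounds cannot be told apart in this test. This first measured pair at this position shows that the hydrogen on this nitrogen is not required for a result in the same range, since a methyl is accepted there. Nothing measured here explains why the swap behaves this way.

A single methyl says little about what larger groups would do, so an ethyl, a longer chain or a chain ending in an amine on the same nitrogen remains an open question. Compound 1 has no reported result, so the effect of its bromine, which stands where compound 2 carries methoxy, cannot be read.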